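Quinoxaline Dioxides: From Acyl Azide to Carbamate

The compounds below may be only part of what the source reports. "The series", "measured", "known", "first", "only" and "open" are said of these compounds alone.

The three measured compounds share a core carrying two N-oxide groups. Compound 1 `CCOc1ccc(/N=C/c2c(-c3ccccc3)[n+]([O-])c3ccc(OC)cc3[n+]2[O-])cc1` gives 64.9% in a functional assay on Ehrlich cells (Mus musculus) for cytotoxicity, read by trypan blue exclusion, with a stated time of 2 h, tested at 50 ug/mL; a higher number here means a weaker effect of the compound at the concentration tested, a lower number a stronger effect. Compound 2 `Cc1c(C(=O)N=[N+]=[N-])[n+]([O-])c2cc(Cl)ccc2[n+]1[O-]` gives 70.3% in this assay, and compound 3 `COc1ccc2c(c1)[n+]([O-])c(C(=O)N=[N+]=[N-])c(C)[n+]2[O-]` gives 6.2%. Among these three numbers compound 2 stands at the high end: compound 1 lies within the scatter of it, while compound 3 is separated from it by the step of a number 64.1 percentage points lower from compound 2 to compound 3 (beyond the scatter), a change of methoxy in place of chloro on an aromatic carbon.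

Compound 4 `Cc1c(NC(=O)OC(C)C)[n+]([O-])c2cc(Cl)ccc2[n+]1[O-]` differs from compound 2 at another site: a group of 7 heavy atoms (4 carbon, 1 nitrogen, 2 oxygen; no ring) in place of a group of 5 heavy atoms (1 carbon, 3 nitrogen, 1 oxygen; no ring), on an aromatic carbon. No measured step touches this site, so the one step shown, from a chloro to a methoxy substituent, does not bear on it, and the data give no direct guide to the direction of the change. Compound 4 is therefore expected to remain close to compound 2, with an estimated step of a number 1.7 percentage points higher from compound 2 to compound 4 (within the scatter) that may well lie within the scatter. The estimated value for compound 4 is 72%, within a wide range from 45% to 95%.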

Compound 4, a percentage reported as activity, at one concentration (the size of the read-out at that concentration, not a potency): 96.3%
Compound 4: the middle estimate sits 24.3 percentage points below what was measured; the whole stated range lies below it.
By their numbers in this assay, from the lowest: compound 3; then compounds 1 and 2 (each within the scatter of the next); then compound 4.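

Within the data shown here, this is the first measured step at the position next to the ring nitrogen, and in this assay it is a step of a number 26 percentage points higher from compound 2 to compound 4 (beyond the scatter) with the chloro held in place. The earlier compounds shown here showed only that the read-out moves with the aromatic chloro or methoxy substituent; this result shows that it also moves with the group at this second site, here towards a weaker effect when (isopropoxycarbonyl)amino enters. No measurement shown accounts for this step.

The compounds shown leave open how a free amine or a carboxylic acid at this position would read. They also leave open whether methoxy in place of chloro would lower the number when (isopropoxycarbonyl)amino is present.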